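The source may hold more compounds than are shown below. What is called first, only, known or untested is meant among the compounds shown, and "the series" means these compounds.

Working notes on the anilino-substituted series

Of the compounds shown here, three of the shared core have been measured in a functional assay on HT29-AK cells (Homo sapiens) for cytotoxicity, read by MTT assay, with a stated time of 48 h; a higher number here means a weaker inhibitor, a lower number a stronger inhibitor. Compound 1 `Fc1cccc(Nc2nc(-c3cccc(F)c3)nc3ccc(F)cc23)c1` carries a 3-fluorophenyl on the nitrogen on the aromatic ring. In this assay compound 1 gives only a limit, > 50000 nM. Compound 2 `Fc1cccc(-c2nc(Nc3ccccc3F)c3cc(F)ccc3n2)c1` carries a 2-fluorophenyl at that nitrogen. In this assay compound 2 also gives only a limit, > 50000 nM. Compound 3 `Fc1cccc(-c2nc(Nc3ccc(Br)cc3)c3cc(F)ccc3n2)c1` carries a 4-bromophenyl there. In this assay compound 3 likewise gives only a limit, > 50000 nM.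

All three values sit at the same limit, (the limit of > 50000 nM in this assay, at which 3 of the 3 values shown sit), so the steps between them cannot be read: a step that the two limits leave unreadable from compound 1 to compound 2, a step that the two limits leave unreadable from compound 1 to compound 3, a step that the two limits leave unreadable from compound 2 to compound 3. Compound 3 therefore stands nowhere in particular relative to compound 1 and compound 2; the numbers show only that none of the three reaches a measurable inhibition.

Compound 4 `Nc1cccc(Nc2nc(-c3cccc(F)c3)nc3ccc(F)cc23)c1` is the next member, not yet measured. Its change from compound 3 is 3-aminophenyl in place of 4-bromophenyl on a nitrogen on an aromatic ring, which introduces one hydrogen-bond donor and one hydrogen-bond acceptor where the 4-bromophenyl had none. Within the data shown here, no measured step gives a readable size for any change at this nitrogen, so no direction can be inferred from them. Compound 4 is expected to stay near the limit, 50000 nM, with a range of 20000 nM to 100000 nM. The step this estimate implies, a number no higher from compound 3 to compound 4 (the limit leaves the size open), is expected to be unreadable as well.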

Compound 4, half-maximal inhibitory concentration: > 50000 nM
Compound 4: only a limit was reported (the forecaster's own chance of this, stated with the estimate: 75%); the middle value lies on the limit itself.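

In this assay compound 4 also gives only a limit, > 50000 nM. Its steps from compound 1, compound 2 and compound 3 therefore cannot be read: the limit of > 50000 nM in this assay, at which 4 of the 4 values shown sit.

The compounds shown leave open whether any group on this nitrogen of the shared core gives a measurable value in this assay.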